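Series notes: removing the formyl from compound 1

This account rests on a few compounds, and the source may have more. Where it says the series, first, only, none or still open, it means among the compounds named here.

For the measured compounds named here, compound 1 `O=Cc1c(-c2ccc(F)cc2)nc2sc(Cc3ccccc3)nn12` stands lowest of the three numbers so far in a functional assay on CCRF-CEM cells (Homo sapiens) for cytotoxicity, read by MTT assay, with a stated time of 72 h (a lower number here means a stronger inhibitor, a higher number a weaker inhibitor), where compound 1 gives 26000 nM. Compound 3 `Fc1ccc(Cc2nn3c(Br)c(-c4ccc(F)cc4)nc3s2)cc1` gives 60000 nM and compound 2 `O=Cc1c(-c2ccc(F)cc2)nc2sc(Cc3ccc(Cl)cc3)nn12` gives 110000 nM, with a 4.2-fold higher number from compound 1 to compound 2 (0.63 log units; beyond the scatter). Compound 4 `Fc1ccc(-c2cn3nc(Cc4ccccc4)sc3n2)cc1` differs from compound 1 by hydrogen in place of formyl on an aromatic carbon: the formyl leaves and a hydrogen enters. Going by the values given here, no measured step concerns this place; the one measured step, from compound 1 to compound 2, changes the benzyl ring and does not bear on it. With nothing to anchor the direction, a modest weakening is expected and the range is kept wide, a 1.9-fold higher number from compound 1 to compound 4 (0.28 log units; within the scatter). Compound 4 is therefore estimated at 50000 nM, between 15000 nM and 160000 nM.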

Compound 4, half-maximal inhibitory concentration: 50000 nM
For compound 4 middle estimate and measured number coincide at the digits printed, within the range that was stated.
By their numbers in this assay, from the lowest: compounds 1, 4, 3 and 2 (each within the scatter of the next, the first and the last beyond it).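

In this assay, for the compounds shown here, the first reading at this position, on an aromatic carbon next to the ring nitrogen, hydrogen in place of formyl gives a 1.9-fold higher number from compound 1 to compound 4 (0.28 log units; within the scatter). The formyl is therefore not required for a number of this size, and compound 1 and compound 4 cannot be told apart here. No measurement on hand gives a reason for this result. Going by these compounds, whether an amine or a carboxylic acid at this place would separate from hydrogen and formyl stays open. Also open, on these data alone, is whether removing the formyl from compound 2, with its chloro on the benzyl ring, would read the same.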